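The source may hold more compounds than are shown below. What is called first, only, known or untested is meant among the compounds shown, and "the series" means these compounds.

Measured so far:
compound 1, `CNC(=O)c1ccc(-c2cc(C(=O)N[C@H]3CCCNC3)c(NC(N)=O)s2)cc1`: 4300 nM
compound 2, `CN(CCN)C(=O)c1cc(-c2ccccc2)sc1NC(N)=O`: "not determined" (no result reported)
compound 3, `NC(=O)Nc1sc(-c2ccccc2)cc1C(=O)NC1CCCCC1`: "not determined" (no result reported)

Among the measured compounds shown here, in a functional assay on HT-29 cells (Homo sapiens) (on this read-out lower numbers stand for an effect already at smaller amounts and higher numbers for an effect only at larger amounts of compound), compound 1 gives 4300 nM, the only number so far. For the measured compounds named here, for compound 2 the entry in this assay reads "not determined" (no result reported), and for compound 3 it likewise reads "not determined" (no result reported); neither contributes a number, so compound 1 stands alone as the reference point, and no step between measured compounds is available.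

Compound 4, `CS(=O)(=O)Nc1ccc(-c2cc(C(=O)N[C@H]3CCCNC3)c(NC(N)=O)s2)cc1`, is the next entry. It differs from compound 1 in one place: methanesulfonamido in place of methylcarbamoyl on an aromatic carbon. The exchange sits on the six-membered aromatic ring, away from the core, and swaps one hydrogen-bond donor bearing group for another that carries one more acceptor. Going by the values given here, with no measured step to lean on, the expected size of the move in this assay is small, within or close to the scatter, with a slight lean toward an effect only at larger amounts. For compound 4 the estimate is 5500 nM, with a range of 1500 nM to 18000 nM, meaning an expected step of a 1.3-fold higher number from compound 1 to compound 4 (0.11 log units; within the scatter).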

Compound 4, half-maximal effective concentration: 2200 nM
Compound 4: the middle estimate sits 2.5-fold (0.40 log units) above what was measured; measured number inside the range.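

In this assay, among the compounds shown here, methanesulfonamido in place of methylcarbamoyl on an aromatic carbon, para to a large group, gives a 2.0-fold lower number from compound 1 to compound 4 (0.29 log units; within the scatter) and is the first readable step. At this position the read-out does not separate the two groups, so the exchange of an amide-type substituent for a sulfonamide-type one, both with a hydrogen-bond donor and no net charge, leaves the result unresolved from that of compound 1. No supporting measurement bears on this step or on any property of either group.

Both groups shown here are uncharged and carry a hydrogen-bond donor, so the response to a methoxy group, which has no such donor, remains open. So does the response to a charged carboxylic acid or amine at this place, or to a longer chain such as ethanesulfonamido.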